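The compounds below may be only part of what the source reports. "The series", "measured", "known", "first", "only" and "open" are said of these compounds alone.

In a physicochemical assay for solubility (on this read-out higher numbers stand for higher solubility and lower numbers for lower solubility), three compounds that share one core have been measured so far. Compound 1 `CN(C)c1ccc(C(=O)N2CCC[C@H]2C(=O)N2CCC(NS(=O)(=O)c3cc(S(=O)(=O)c4ccccc4)ccc3C(F)(F)F)CC2)cc1` gives 100000 nM, compound 2 `O=C([C@@H]1CCCN1C(=O)c1ccncc1)N1CCC(NS(=O)(=O)c2cc(S(=O)(=O)c3ccccc3)ccc2C(F)(F)F)CC1` gives 100000 nM, and compound 3 `CC(C)(C)NC(=O)N1CCC[C@H]1C(=O)N1CCC(NS(=O)(=O)c2cc(S(=O)(=O)c3ccccc3)ccc2C(F)(F)F)CC1` gives 50000 nM. Compound 3 therefore stands within the scatter of both the others, and these numbers do not rank the three.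

Compound 4 `O=C([C@@H]1CCCN1C(=O)N1CCOCC1)N1CCC(NS(=O)(=O)c2cc(S(=O)(=O)c3ccccc3)ccc2C(F)(F)F)CC1` differs from compound 3 at one place, on a carbonyl carbon: morpholin-4-yl in place of (tert-butyl)amino on a carbonyl carbon. The measured steps that bear on this change are those made at the same carbonyl carbon: no change at the digits printed from compound 1 to compound 2 (within the scatter), a 2.0-fold lower number from compound 1 to compound 3 (0.30 log units; within the scatter) and a 2.0-fold lower number from compound 2 to compound 3 (0.30 log units; within the scatter). All three lie within the scatter. None of them involves morpholin-4-yl, so the evidence is only indirect, and no step beyond the scatter is expected in this assay. The expected step is a 1.4-fold higher number from compound 3 to compound 4 (0.15 log units; within the scatter), which would be too small to give a meaningful direction. Compound 4 is estimated at 70000 nM, with an expected range of 35000 nM to 120000 nM.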

Compound 4, solubility: 50000 nM
For compound 4 the middle estimate is 1.4-fold (0.15 log units) above the measured one, and the stated range covers the measured number.
By their numbers in this assay, from the lowest: compounds 3, 4, 1 and 2 (each within the scatter of the next).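

In this assay, exchanging (tert-butyl)amino, with its hydrogen-bond donor, for morpholin-4-yl, a six-membered ring with no donor, gives a step within the scatter (no change at the digits printed from compound 3 to compound 4 (within the scatter)). The comparisons with the two aromatic groups on the same carbonyl carbon also stay within the scatter (a 2.0-fold lower number from compound 2 to compound 4 (0.30 log units; within the scatter)) and (a 2.0-fold lower number from compound 1 to compound 4 (0.30 log units; within the scatter)), so none of the four groups shown at this place separates from the others on this read-out. Nothing measured here offers an explanation for these numbers.

From the compounds shown here alone, whether a carboxylic acid or a longer alkyl chain on this carbonyl carbon would produce a step beyond the scatter remains open. The compounds also leave open whether replacing the trifluoromethyl group elsewhere on the shared core would do so.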